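A few compounds are considered here, and "the series" means these few. Any claim that something is new, unique, unknown or untested is made for them only; others in the source may bear on it.

In a functional assay on HepG2 cells (Homo sapiens) for antiproliferative activity, read by MTT assay, with a stated time of 24 h (on this read-out higher numbers stand for weaker inhibition and lower numbers for stronger inhibition), compound 1 `COc1ccc(C(=O)/C=C/c2ccc(N(C)C)cc2)c2c1C=CC(C)(C)O2` gives 730 nM and compound 2 `COc1ccc(C(=O)/C=C/c2ccc([N+](=O)[O-])cc2)c2c1C=CC(C)(C)O2` gives 2610 nM. Between them lies a 3.6-fold higher number from compound 1 to compound 2 (0.55 log units; beyond the scatter). Compound 3 `COc1ccc(C(=O)/C=C/c2ccc(Cl)c(Cl)c2)c2c1C=CC(C)(C)O2` gives > 10000 nM, which is a limit of the assay and not a number. Among the measured compounds shown here, it is the only such reading: the limit of > 10000 nM in this assay, at which 1 of the 3 values shown sits.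

The next change leads to compound 4 `COc1ccc(C(=O)/C=C/c2cccc(O)c2)c2c1C=CC(C)(C)O2`, with 3-hydroxyphenyl in place of 3,4-dichlorophenyl on a double-bonded chain carbon bound to a double-bonded chain carbon. For the measured compounds named here, two measured steps bear on this, both introducing the 3,4-dichlorophenyl group. One is large, an at least 13-fold higher number from compound 1 to compound 3 (1.13 log units; beyond the scatter). The other is at least modest, an at least 3.8-fold higher number from compound 2 to compound 3 (0.58 log units; beyond the scatter). Neither introduces or removes 3-hydroxyphenyl, so the transfer is uncertain, but a modest or larger move towards a lower number is expected. The estimated step is an at least 3.3-fold lower number from compound 3 to compound 4 (0.52 log units; beyond the scatter). Compound 4 is expected at 3000 nM, with an estimated range of 800 nM to 10000 nM.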

Compound 4, half-maximal inhibitory concentration: > 10000 nM
Compound 4 gave a limit, no number (the forecaster's own chance of this, stated with the estimate: 25%); at least 3.3-fold (0.52 log units) between middle value and limit.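

The reading for compound 4 is a limit of the assay and not a number, as is the reading for compound 3, so the step between them cannot be read. On the double-bonded chain carbon, 3-hydroxyphenyl therefore gives no number, although it brings a hydrogen-bond donor that 3,4-dichlorophenyl lacks: the limit of > 10000 nM in this assay, at which 2 of the 4 values shown sit. Both groups stay clearly behind the two that give numbers, with an at least 13-fold higher number from compound 1 to compound 4 (1.13 log units; beyond the scatter) and an at least 3.8-fold higher number from compound 2 to compound 4 (0.58 log units; beyond the scatter).

Open, from the compounds shown here alone, is whether 4-hydroxyphenyl or 4-aminophenyl on the same carbon would give a number in this assay. Going by these compounds, how far compound 3 and compound 4 lie past the limit also remains unknown.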